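This account rests on a few compounds, and the source may have more. Where it says the series, first, only, none or still open, it means among the compounds named here.

Three analogues of a shared dihydropyranone core serve as the starting points. Compound 1 `Cc1cc(-c2cc(Cl)cc(C)c2/C=C/[C@@H]2C[C@@H](O)CC(=O)O2)ccc1F` shows the strongest inhibition in an assay for inhibition of 3-hydroxy-3-methylglutaryl-coenzyme A reductase (Rattus norvegicus) (on this read-out higher numbers stand for weaker inhibition and lower numbers for stronger inhibition), where compound 1 gives 6 nM. Compound 2 `O=C1C[C@H](O)C[C@@H](/C=C/c2c(Cl)cc(Cl)cc2-c2ccccc2)O1` stands second among the three numbers: in this assay compound 2 gives 80 nM, a weaker result than compound 1 by a margin beyond the scatter, yet far stronger than compound 3 `O=C1C[C@H](O)C[C@@H](/C=C/c2ccccc2-c2ccccc2)O1`, which in this assay gives 3000 nM. The two ends of this spread differ in both the halogen pattern of the core and the decoration of the pendant phenyl, so the data do not separate the two contributions.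

Compound 4 `COc1cccc(-c2cc(Cl)cc(Cl)c2/C=C/[C@@H]2C[C@@H](O)CC(=O)O2)c1` takes compound 2 as its template and changes only one place: methoxy in place of hydrogen on an aromatic carbon. For the measured compounds named here, no measured pair isolates this change. Compound 1 indicates that a decorated pendant phenyl can sit with a low number, so the step is expected to run toward stronger inhibition, though only modestly, with a 2.0-fold lower number from compound 2 to compound 4 (0.30 log units; within the scatter) as the expected size. Compound 4 is therefore estimated at 40 nM, with a likely range from 10 nM to 160 nM.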

Compound 4, half-maximal inhibitory concentration: 50 nM
Compound 4: middle estimate off by 1.3-fold (0.10 log units), on the low side, and the stated range covers the measured number.
By their numbers in this assay, from the lowest: compound 1; then compounds 4 and 2 (each within the scatter of the next); then compound 3.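

In this assay the first step measured at this position reads a 1.6-fold lower number from compound 2 to compound 4 (0.20 log units; within the scatter), so compounds 2 and 4 cannot be told apart on this read-out. For the compounds shown here, this single-place comparison shows that, in this series, replacing phenyl with 3-methoxyphenyl gives a value within the scatter of the parent, which the earlier compounds, each differing in more than one place, could not show. No evidence is available to explain this result.

From the compounds shown here alone, whether an amine, a carboxylic acid or a longer chain such as butoxy at this position would move the number beyond the scatter remains open. Also open, going by these compounds, is how much the decoration of the pendant phenyl in compound 1 contributes apart from the halogen pattern of its core.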